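Compound 3 and a change on the carbonyl carbon

The source may report more compounds than this note shows. Statements on the series, on what has been measured and on what is new or still open speak of the compounds shown alone.

Measured in an ADME assay on HEK293 cells (Homo sapiens) for cytotoxicity, read by MTT assay, with a stated time of 72 h; on this read-out higher numbers stand for weaker inhibition and lower numbers for stronger inhibition:
Compound 1 (`COc1cccc(C(=O)N2CCN(CC(=O)N3CCN(CCCc4c[nH]c5ccccc45)CC3)CC2)c1`): 143000 nM
Compound 2 (`O=C(CN1CCN(C(=O)c2ccc(F)cc2)CC1)N1CCN(CCCc2c[nH]c3ccc(F)cc23)CC1`): 102000 nM

Compound 2, at 102000 nM, stands within the scatter of compound 1, at 143000 nM. Compound 3 (`COc1cccc(C(=O)N2CCN(CC(=O)N3CCN(CCCc4c[nH]c5ccc(F)cc45)CC3)CC2)c1`) has not yet been measured. It differs from compound 2 by 3-methoxyphenyl in place of 4-fluorophenyl on a carbonyl carbon. Going by the values given here, no measured pair isolates this change, so its size cannot be read directly from the data. No step beyond the scatter is expected in this assay, and the expected change is a 1.2-fold higher number from compound 2 to compound 3 (0.07 log units; within the scatter). For compound 3 the estimated value is 120000 nM, with an expected range of 60000 nM to 240000 nM.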

Compound 3, half-maximal inhibitory concentration: 87100 nM
Estimate against measurement, compound 3: 1.4-fold (0.14 log units) above; the measured number falls inside the stated range.
By their numbers in this assay, from the lowest: compounds 3, 2 and 1 (each within the scatter of the next).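

In this assay, 3-methoxyphenyl in place of 4-fluorophenyl on the carbonyl carbon gives a 1.2-fold lower number from compound 2 to compound 3 (0.07 log units; within the scatter) and so shows that this exchange of aromatic groups leaves the read-out within the scatter. Going by these compounds alone, the same compound also isolates fluoro in place of hydrogen on an aromatic carbon for the first time, with a 1.6-fold lower number from compound 1 to compound 3 (0.22 log units; within the scatter) as the result. No supporting measurement bears on either step.

The compounds shown leave open whether an amine or a carboxylic acid on this carbonyl carbon would give a step beyond the scatter.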